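A few compounds are considered here, and "the series" means these few. Any claim that something is new, unique, unknown or untested is made for them only; others in the source may bear on it.

Compound 2, `N#Cc1ccc(O[C@H]2CN(S(=O)(=O)c3ccc(Cl)cc3Cl)C[C@H]2O)cc1F`, was tested in an assay on cells for antagonist activity at transient receptor potential cation channel subfamily V member 4 (Homo sapiens), read by FLIPR and calcium flux, with a stated time of 10 min (on this read-out higher numbers stand for weaker inhibition and lower numbers for stronger inhibition), where compound 2 gives 100 nM. This is the lowest of the two numbers recorded so far. The other measured compound, compound 1, `N#Cc1ccc(O[C@H]2CN(S(=O)(=O)c3ccc(Cl)cc3Cl)C[C@@H]2CO)cc1F`, carries a hydroxymethyl group in place of the hydroxyl; in this assay compound 1 gives 200 nM, a number that sits close to compound 2 within the usual scatter, so the two cannot be ranked against each other.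

Compound 3, `N#Cc1ccc(O[C@H]2CN(S(=O)(=O)c3ccc(Cl)cc3Cl)C[C@@H]2O)cc1F`, is the mirror-image partner of compound 2 at one position: the two compounds have the same atoms and bonds and differ only in configuration as drawn: 1 of 2 stereo elements differ; a stereocentre at a saturated ring carbon is drawn R in compound 2 and S in compound 3. Flipping the configuration of a ring stereocentre that carries the hydroxyl often changes how well a molecule fits, and it can do so in either direction; nothing measured here tells which way. Among the measured compounds shown here, with no comparable step to lean on, a modest loss seems the safer expectation.

For compound 3 in this assay the estimate is 300 nM, with a plausible range from 60 nM to 2000 nM. That expected change from compound 2 to compound 3 in this assay is a 3.0-fold higher number from compound 2 to compound 3 (0.48 log units; beyond the scatter).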

Compound 3, half-maximal inhibitory concentration: 40 nM
Beside the measured number, compound 3's estimate is 7.5-fold (0.88 log units) above it, and the stated range ends above it.
By their numbers in this assay, from the lowest: compound 3; then compounds 2 and 1 (each within the scatter of the next).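

In this assay, the configuration at this saturated ring carbon now has a readable effect: flipping it brings a 2.5-fold lower number from compound 2 to compound 3 (0.40 log units; beyond the scatter) and gives a separation that the earlier pair, which could not be ranked, did not offer. This step can be traced to the configuration as drawn, because no atom or bond changes: the fact that compounds 2 and 3 differ only in the configuration as drawn. Hydroxy in place of hydroxymethyl also now gives a readable step, a 5.0-fold lower number from compound 1 to compound 3 (0.70 log units; beyond the scatter), which leaves the hydroxy group in the configuration of compound 3 with the lowest number of the three.

The compounds shown leave open whether the hydroxymethyl group would respond to the same flip of configuration. They also leave open whether a methoxy group or an amine at this carbon, in the configuration of compound 3, would keep a number this low.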